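This account rests on a few compounds, and the source may have more. Where it says the series, first, only, none or still open, it means among the compounds named here.

Measured so far:
- compound 1, `CCOC(=O)C1=C(C)NC(CCl)=C(C(=O)OCC)C1c1cccc([N+](=O)[O-])c1`: 53 nM
- compound 2, `C=CCOC(=O)C1=C(C)NC(C)=C(C(=O)OC)C1c1cccc([N+](=O)[O-])c1`: 15 nM
- compound 3, `CCOC(=O)C1=C(C)NC(C)=C(C(=O)OCc2ccc([N+](=O)[O-])cc2)C1c1cccc([N+](=O)[O-])c1`: 140 nM

These three compounds share a core and were tested in a functional assay on HEK293 cells for antagonist activity at Voltage-dependent L-type calcium channel subunit alpha-1D (Rattus norvegicus), read by FLIPR; a lower number here means a stronger inhibitor, a higher number a weaker inhibitor. Compound 2 gives the lowest number of the three, and its gaps to compound 1 and to compound 3 both lie beyond the usual scatter, so on these numbers compound 2 is the strongest inhibitor. Compound 3, which carries the largest group on the oxygen next to a carbonyl group, gives the highest number.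

The next compound, compound 4, `COC(=O)C1=C(C)NC(C)=C(C(=O)OCCCOc2ccccc2)C1c1cccc([N+](=O)[O-])c1`, has not yet been measured in this assay. It differs from compound 2 in one place: 2-phenoxyethyl in place of vinyl on a saturated chain carbon bound to an oxygen next to a carbonyl group. Among the compounds with values here, no measured pair shows exactly this change, so its effect can only be guessed from the numbers above, where the bulkier group of compound 3 went with a weaker result. A modest move toward a higher number is expected, possibly within the scatter. Compound 4 is therefore expected to give about 30 nM, likely between 8 nM and 120 nM, which would mean an estimated step of a 2.0-fold higher number from compound 2 to compound 4 (0.30 log units; within the scatter).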

Compound 4, half-maximal inhibitory concentration: 11 nM
Estimate against measurement, compound 4: 2.7-fold (0.44 log units) above; the range from low to high includes it.
By their numbers in this assay, from the lowest: compounds 4 and 2 (each within the scatter of the next); then compound 1; then compound 3.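

In this assay the change from vinyl to 2-phenoxyethyl, on a saturated chain carbon bound to an oxygen next to a carbonyl group, gives a 1.4-fold lower number from compound 2 to compound 4 (0.13 log units; within the scatter) and so leaves the number effectively unchanged. In this one pair, a group of 9 heavy atoms with a six-membered aromatic ring replaces one of 2 heavy atoms, with no step beyond the scatter. Nothing shown here explains why the number holds.

The compounds shown leave open whether other groups at this place would behave the same way, such as a chain ending in an amine or a carboxylic acid, or a longer chain ending in the same phenoxy group. Within the data shown here, they also leave open how much the chain and the aromatic ring each contribute, as no pair here separates the two.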